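The compounds below may be only part of what the source reports. "The series", "measured", "known", "first", "only" and "open" are said of these compounds alone.

Three compounds sharing one core differ in the group on a saturated ring carbon: compound 1 `COc1ccc(C2OC(c3ccc4ccccc4c3)=NN2C(C)=O)cc1`, compound 2 `CC(=O)N1N=C(c2ccc3ccccc3c2)OC1c1ccccc1Br` and compound 3 `CC(=O)N1N=C(c2ccc3ccccc3c2)OC1c1cccc(Br)c1`. In a functional assay on B16-F10 cells (Mus musculus) for antiproliferative activity, read by MTT assay, with a stated time of 48 h (on this read-out higher numbers stand for weaker inhibition and lower numbers for stronger inhibition), compound 3 gives 2.36 ug/mL, the lowest of the three numbers, while compound 1 gives 6.86 ug/mL and compound 2 gives 6.98 ug/mL. The next compound, compound 4 `CC(=O)N1N=C(c2ccc3ccccc3c2)OC1c1ccc(Br)cc1`, carries 4-bromophenyl in place of 3-bromophenyl on a saturated ring carbon.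

Two measured steps lead to compound 3, and both are modest: a 2.9-fold lower number from compound 1 to compound 3 (0.46 log units; beyond the scatter) and a 3.0-fold lower number from compound 2 to compound 3 (0.47 log units; beyond the scatter). The third step, a 1.0-fold higher number from compound 1 to compound 2 (0.01 log units; within the scatter), separates nothing. So far, then, compound 3 stands alone, and no measured compound carries 4-bromophenyl. Going by compound 2, the other bromophenyl compound, at 6.98 ug/mL, a modest move to a higher number in this assay is expected, though a step within the scatter remains possible. The expected change is a 2.1-fold higher number from compound 3 to compound 4 (0.33 log units; beyond the scatter). Compound 4 is estimated at 5 ug/mL, with an expected range of 2 ug/mL to 11 ug/mL.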

Compound 4, half-maximal inhibitory concentration: 4.68 ug/mL
For compound 4 the middle estimate is 1.1-fold (0.03 log units) above the measured one; the measured number falls inside the stated range.
By their numbers in this assay, from the lowest: compounds 3, 4, 1 and 2 (each within the scatter of the next, the first and the last beyond it).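

In this assay, 4-bromophenyl on the saturated ring carbon cannot be told apart from 3-bromophenyl, with a 2.0-fold higher number from compound 3 to compound 4 (0.30 log units; within the scatter), or from 2-bromophenyl, with a 1.5-fold lower number from compound 2 to compound 4 (0.17 log units; within the scatter), even though compound 2 and compound 3 are separated from each other. Bromo in place of methoxy on an aromatic carbon also separates nothing, with a 1.5-fold lower number from compound 1 to compound 4 (0.17 log units; within the scatter). The one-place changes at this position therefore remain small, and the data offer no explanation for these numbers.

From the compounds shown here alone, whether an amine or a carboxylic acid on this aromatic ring would give a step clearly beyond the scatter remains open. So does the effect of replacing the acetyl group with a longer chain, or the bromophenyl group with a simple methyl group.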